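Aryl Swap on the Pyridazinone Nitrogen, Two Cores

The source may hold more compounds than are shown below. What is called first, only, known or untested is meant among the compounds shown, and "the series" means these compounds.

Measured so far:
compound 1 `CNC(=O)c1cc(Oc2ccc(NC(=O)c3nn(-c4ccccc4OC(F)(F)F)c(=O)cc3C)cc2F)ccn1` — > 40000 nM
compound 2 `CNC(=O)c1cc(Oc2ccc(NC(=O)c3nn(-c4cccc(F)c4)c(=O)cc3C)cc2F)ccn1` — 9540 nM
compound 3 `Cc1cc(=O)n(-c2ccccc2OC(F)(F)F)nc1C(=O)Nc1ccc(Oc2ncnc3ccsc23)c(F)c1` — 5720 nM

In a functional assay on A549 cells (Homo sapiens) for cytotoxicity, read by MTT assay, with a stated time of 72 h (a higher number here means a weaker inhibitor, a lower number a stronger inhibitor), compound 1 reaches only a limit, > 40000 nM, and that is all its value states (the limit of > 40000 nM in this assay, at which 1 of the 3 values shown sits). Compound 2 gives 9540 nM in this assay. Compound 3 gives 5720 nM in this assay; its value and that of compound 2 lie within the scatter of each other, so no order between them is claimed.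

Two changes start from compound 1. The first, (3-fluorophenyl in place of 2-(trifluoromethoxy)phenyl on an aromatic nitrogen), brings an at least 4.1-fold lower number from compound 1 to compound 2 (0.62 log units; beyond the scatter). The second, (a group of 9 heavy atoms (6 carbon, 2 nitrogen, 1 sulfur; one five-membered aromatic ring with 1 hetero atom, one six-membered aromatic ring with 2 hetero atoms) in place of a group of 10 heavy atoms (7 carbon, 2 nitrogen, 1 oxygen; one six-membered aromatic ring with 1 hetero atom), on an oxygen on an aromatic ring), brings an at least 6.9-fold lower number from compound 1 to compound 3 (0.84 log units; beyond the scatter). Both steps start from a limit, so only their lower bound is known.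

Compound 4 `Cc1cc(=O)n(-c2cccc(F)c2)nc1C(=O)Nc1ccc(Oc2ncnc3ccsc23)c(F)c1` is not yet measured. Against compound 3 it shows (3-fluorophenyl in place of 2-(trifluoromethoxy)phenyl on an aromatic nitrogen), which is the same change as the one from compound 1 to compound 2, made on the core of compound 3 rather than on the core of compound 1; how the two cores differ is set out above as a group of 9 heavy atoms (6 carbon, 2 nitrogen, 1 sulfur; one five-membered aromatic ring with 1 hetero atom, one six-membered aromatic ring with 2 hetero atoms) in place of a group of 10 heavy atoms (7 carbon, 2 nitrogen, 1 oxygen; one six-membered aromatic ring with 1 hetero atom), on an oxygen on an aromatic ring. The surroundings of the place are described in the same words for both pairs.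

For compound 4 the expected step in this assay is a 3.2-fold lower number from compound 3 to compound 4 (0.50 log units; beyond the scatter), which rests on an at least 4.1-fold lower number from compound 1 to compound 2 (0.62 log units; beyond the scatter), taken as a lower bound with an unknown true size. In this assay compound 4 is estimated at 1800 nM, expected to fall between 600 nM and 5000 nM.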

Compound 4, half-maximal inhibitory concentration: 5220 nM
Compound 4: the middle estimate sits 2.9-fold (0.46 log units) below what was measured; the measured number lies above the stated range.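

In this assay, the change to 3-fluorophenyl in place of 2-(trifluoromethoxy)phenyl does not carry over from the core of compound 1 to the core of compound 3, where it gives a 1.1-fold lower number from compound 3 to compound 4 (0.04 log units; within the scatter), and the two steps differ: the same change on two cores in this assay, an at least 4.1-fold lower number (0.62 log units; beyond the scatter) from compound 1 to compound 2 and a 1.1-fold lower number (0.04 log units; within the scatter) from compound 3 to compound 4, at least 3.8-fold (0.58 log units) apart, beyond the scatter of two such steps

Read the other way, the core change gives a 1.8-fold lower number from compound 2 to compound 4 (0.26 log units; within the scatter) with 3-fluorophenyl on the aromatic nitrogen, so the two cores cannot be told apart with this group, whereas they can with 2-(trifluoromethoxy)phenyl: the same change on two cores in this assay, an at least 6.9-fold lower number (0.84 log units; beyond the scatter) from compound 1 to compound 3 and a 1.8-fold lower number (0.26 log units; within the scatter) from compound 2 to compound 4, at least 3.8-fold (0.58 log units) apart, beyond the scatter of two such steps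

Compound 1 stands at a limit, so the size of each step from it and of each gap remains a lower bound, and this single pair of cores and pair of aryl groups shows a failure to transfer in this case only, neither a rule for the series nor a reason for the failure: the limit of > 40000 nM in this assay, at which 1 of the 4 values shown sits.

Still open, going by these compounds, is whether other groups on the aromatic nitrogen, such as a plain phenyl or a pyridyl, would behave like 3-fluorophenyl or like 2-(trifluoromethoxy)phenyl on the two cores. Also open, on these data alone, is whether an amine or a carboxylic acid on that aryl ring would shift the values on either core.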